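Swapping the pyridine amide for a cyanothiazole amide

The compounds below may be only part of what the source reports. "The series", "measured", "known", "first", "only" and "open" are said of these compounds alone.

Among the compounds with values here, the two compounds measured so far share one core and differ only in the ring attached to the amide nitrogen. Compound 1 `CC(C)[C@H](C(=O)Nc1ccccn1)c1ccc(Cl)cc1` carries a pyridin-2-yl ring and in a functional assay on CHO cells for agonist activity at Free fatty acid receptor 2 (Homo sapiens), read by cAMP accumulation (on this read-out lower numbers stand for stronger inhibition and higher numbers for weaker inhibition), gives 1400 nM, the lower of the two numbers seen. Compound 2 `CC(C)[C@H](C(=O)Nc1nc(C(F)(F)F)cs1)c1ccc(Cl)cc1` carries a thiazole ring bearing trifluoromethyl and in this assay gives 17000 nM, a number beyond the usual scatter above that of compound 1.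

Compound 3 `CC(C)[C@H](C(=O)Nc1ncc(C#N)s1)c1ccc(Cl)cc1` has not been measured. It differs from compound 1 as follows: 5-cyano-1,3-thiazol-2-yl in place of pyridin-2-yl on an amide-type nitrogen. Compound 3 is expected to be a weaker agonist than compound 1, with an estimated step of a 3.6-fold higher number from compound 1 to compound 3 (0.55 log units; beyond the scatter) in this assay, because the other thiazole-bearing compound 2 gives 17000 nM while compound 1 gives 1400 nM. For compound 3 the estimate is 5000 nM, between 1500 nM and 20000 nM.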

Compound 3, half-maximal inhibitory concentration: 2000 nM
Beside the measured number, compound 3's estimate is 2.5-fold (0.40 log units) above it; low and high end bracket the measured number.
By their numbers in this assay, from the lowest: compounds 1 and 3 (each within the scatter of the next); then compound 2.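

In this assay, placing 5-cyano-1,3-thiazol-2-yl instead of pyridin-2-yl on the amide-type nitrogen gives a 1.4-fold higher number from compound 1 to compound 3 (0.15 log units; within the scatter), so at this position a five-membered ring can read the same as the six-membered ring of compound 1. A thiazole ring here is therefore not tied to a weak number: compound 3 gives 2000 nM, whereas compound 2, with its trifluoromethyl-bearing thiazole, gives 17000 nM. Nothing available explains why compound 1 and compound 3 read alike or why compound 2 stands apart.

The compounds shown leave open how much of the gap between compound 2 and compound 3 comes from the group on the thiazole and how much from where it sits. A thiazole with no added group, or one carrying an amine or a carboxylic acid, would help separate those two questions.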